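From 3-methylphenyl to 3-methoxyphenyl: a small expected step

The source may report more compounds than this note shows. Statements on the series, on what has been measured and on what is new or still open speak of the compounds shown alone.

Going by the values given here, in a functional assay on MDA-MB-231 cells (Homo sapiens) for antiproliferative activity, read by MTT assay, with a stated time of 72 h (on this read-out higher numbers stand for weaker inhibition and lower numbers for stronger inhibition), compound 3 (`COc1cc(-c2nccn2-c2cccc(C)c2)cc(OC)c1OC`) gives 11700 nM as the only actual number. For compound 1 (`COc1cc(-c2nccn2CC(C)C)cc(OC)c1OC`) the result > 100000 nM is a limit and not a number. For compound 2 (`COc1cc(-c2nccn2Cc2ccccc2)cc(OC)c1OC`) the result > 100000 nM is likewise a limit. Between these two, the data show a step that the two limits leave unreadable from compound 1 to compound 2 and nothing more.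

Compound 4 (`COc1cccc(-n2ccnc2-c2cc(OC)c(OC)c(OC)c2)c1`) differs from compound 3 by one swap (methoxy in place of methyl on an aromatic carbon) that turns 3-methylphenyl into 3-methoxyphenyl.

Two measured steps in this assay bear on this change only indirectly. One is an at least 8.5-fold lower number from compound 1 to compound 3 (0.93 log units; beyond the scatter) and the other is an at least 8.5-fold lower number from compound 2 to compound 3 (0.93 log units; beyond the scatter) and both put 3-methylphenyl on an aromatic nitrogen, in place of isobutyl in the first and benzyl in the second. Compound 4 keeps that ring and alters only its methyl. Among the compounds with values here, no measured step touches that methyl, so the expectation rests on compound 3 at 11700 nM and no step beyond the scatter is expected. The estimated change is a 1.3-fold lower number from compound 3 to compound 4 (0.11 log units; within the scatter) in all. Compound 4 is expected at 9000 nM (estimated range 2500 nM to 35000 nM).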

Compound 4, half-maximal inhibitory concentration: 18300 nM
Compound 4: the middle estimate sits 2.0-fold (0.31 log units) below what was measured, and the stated range covers the measured number.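

In this assay, the aromatic carbon that carries the methyl of compound 3 now has its first readable change: methoxy in place of methyl gives a 1.6-fold higher number from compound 3 to compound 4 (0.19 log units; within the scatter), so this swap does not separate the two compounds. The 3-methoxyphenyl ring also keeps the separation from the two groups without a ring directly on the aromatic nitrogen, with an at least 5.4-fold lower number from compound 2 to compound 4 (0.73 log units; beyond the scatter) and an at least 5.4-fold lower number from compound 1 to compound 4 (0.73 log units; beyond the scatter), so among the four compounds shown this separation does not depend on 3-methylphenyl alone, and none of them goes against it. On these data alone, these two steps start from limits and not from numbers, so their full size stays unknown, and the step between compound 1 and compound 2 cannot be read at all, as both of those compounds sit at the same limit: the limit of > 100000 nM in this assay, at which 2 of the 4 values shown sit.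

The compounds shown leave open whether another group on this aromatic carbon, such as chlorine, a hydroxyl or an amine, would move the number beyond the scatter. They also leave open how an unsubstituted phenyl on the aromatic nitrogen, or methoxy on a different carbon of that ring, would read in this assay.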